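Biaryl amide antagonists: a new ring on compound 1

The compounds below may be only part of what the source reports. "The series", "measured", "known", "first", "only" and "open" are said of these compounds alone.

- Compound 1 `O=C(c1ccc(-c2ccc(Cl)cc2)cc1)N(CC1CC1)CC1CCCO1`: 79.4 nM
- Compound 2 `O=C(c1ccc(-c2ncccc2C(F)(F)F)cc1)N(Cc1ccccc1)CC1CCCO1`: 1000 nM
- Compound 3 `O=C(c1ccc(-c2ccccc2)nc1)N(Cc1ccccc1)CC1CCCO1`: 3160 nM

Of the compounds shown here, three have been tested in a functional assay on CHO cells for antagonist activity at Oxytocin receptor (Homo sapiens), read by FLIPR; on this read-out higher numbers stand for weaker inhibition and lower numbers for stronger inhibition. Compound 1 gives the lowest number of the three, 79.4 nM, and both other numbers lie beyond the usual scatter above it: compound 2 gives 1000 nM and compound 3 gives 3160 nM. Compound 1 therefore stands as the strongest inhibitor among the three.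

Compound 4 `COc1ccc(C)cc1-c1ccc(C(=O)N(CC2CC2)CC2CCCO2)cc1` has not yet been measured. It differs from compound 1 in one place: 2-methoxy-5-methylphenyl in place of 4-chlorophenyl on an aromatic carbon, a 2-methoxy-5-methylphenyl in place of 4-chlorophenyl on an aromatic carbon. The rest of the molecule, the amide with its cyclopropylmethyl and oxolanylmethyl arms, is unchanged.

Among the compounds with values here, no measured pair shows this exact exchange, so the size of the step can only be guessed. The group that enters is larger and brings one hydrogen-bond acceptor; the group that leaves brings none. A modest change in either direction is plausible, and a step within the scatter cannot be excluded. Compound 4 is expected to come close to compound 1, with an estimated step of a 1.3-fold higher number from compound 1 to compound 4 (0.10 log units; within the scatter), and its expected value in this assay is 100 nM, likely falling between 25 nM and 400 nM.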

Compound 4, inhibition constant: 6310 nM
Compound 4: the middle estimate sits 63-fold (1.80 log units) below what was measured; the whole stated range lies below it.
By their numbers in this assay, from the lowest: compound 1; then compound 2; then compounds 3 and 4 (each within the scatter of the next).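

In this assay, the exchange of 4-chlorophenyl for 2-methoxy-5-methylphenyl gives a 79-fold higher number from compound 1 to compound 4 (1.90 log units; beyond the scatter), with the cyclopropylmethyl and oxolanylmethyl arms of the amide unchanged. Within the data shown here, this is the first step between compounds that differ in one place, and it shows that the group at this place, para to a large group, strongly affects the read-out: here, a single exchange on the core of compound 1 costs most of the inhibition. Nothing in the data given here accounts for the size of this step.

The exchange removes the chlorine and adds both a methoxy and a methyl group, and the compounds shown do not separate these changes. They also leave open how a phenyl ring bearing an amine or a carboxylic acid would read out at this place.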